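A few compounds are considered here, and "the series" means these few. Any claim that something is new, unique, unknown or untested is made for them only; others in the source may bear on it.

Compound 3 `CCOC(=O)C1CCCN(Cc2cn(CC(O)COC(=O)NCc3ccccc3)nn2)C1` stands highest of the three compounds measured in an assay on nucleic acid for inhibition of Nucleic Acid, read by fluorescence, tested at 100 uM (a lower number here means less inhibition, a higher number more inhibition at the concentration tested (going by the name of the read-out)), where compound 3 gives 47%. Compound 2 `CN(CCCc1ccccc1)Cc1cn(CC(O)COCc2ccccc2)nn1` gives 18%, and compound 1 `CCOC(=O)C1CCCN(Cc2cn(CC(O)COC(=O)c3ccccc3)nn2)C1` gives 6%. Among the compounds with values here, the only single-point step measured, a number 41 percentage points higher from compound 1 to compound 3 (beyond the scatter), came with benzylamino in place of phenyl on a carbonyl carbon. Compound 4 `CCOC(=O)C1CCCN(Cc2cn(CC(O)COCc3ccccc3)nn2)C1` differs from compound 3 by benzyl in place of benzylcarbamoyl on an oxygen on a saturated carbon. This change takes away the carbamoyl part whose arrival brought the large gain seen in a number 41 percentage points higher from compound 1 to compound 3 (beyond the scatter), and compound 2, which also bears a benzyl, gives 18%. A downward step in this assay is therefore expected for compound 4, estimated at a number 32 percentage points lower from compound 3 to compound 4 (beyond the scatter). Compound 4 is expected to give about 15% in this assay, within 3% to 35%.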

Compound 4, a percentage reported as inhibition, at one concentration (the size of the read-out at that concentration, not a potency): 26%
The estimate for compound 4 lay 11 percentage points below the measured number, within the range that was stated.
By their numbers in this assay, from the lowest: compound 1; then compounds 2 and 4 (each within the scatter of the next); then compound 3.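

On the oxygen on a saturated carbon, benzyl in place of benzylcarbamoyl brings a number 21 percentage points lower from compound 3 to compound 4 (beyond the scatter) in this assay, while benzyl in place of benzoyl brings a number 20 percentage points higher from compound 1 to compound 4 (beyond the scatter). Among these three groups, benzyl therefore takes the middle place, so part of the gain seen with benzylcarbamoyl remains without the carbamoyl part. Nothing available explains this order. As far as these compounds go, it remains open whether the amide hydrogen or the carbonyl accounts for the difference, and how a free hydroxyl or a longer phenylpropyl chain on this oxygen would stand.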